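Chain shape at the core nitrogen: compound 1 to compound 4

The compounds below may be only part of what the source reports. "The series", "measured", "known", "first", "only" and "open" are said of these compounds alone.

Within the data shown here, compound 1 `CC(C)Cn1c(CN2CCN(C(=O)C3CC3)CC2)nc2ccccc21` stands lowest of the three compounds measured so far in an assay on isolated protein for inhibition of aldehyde dehydrogenase 1A1 (Homo sapiens), read by spectrophotometry, tested at 10 uM; on this read-out higher numbers stand for more inhibition at the one concentration tested (going by the name of the read-out) and lower numbers for less inhibition; compound 1 gives 13.1%. Compound 2 `Cc1cccc(Cn2c(CN3CCN(C(=O)c4ccc(Cl)cc4)CC3)nc3ccccc32)c1` gives 23.2%, and compound 3 `Cc1cccc(Cn2c(CN3CCN(C(=O)c4ccc(Br)cc4)CC3)nc3ccccc32)c1` gives 25.8%, each of them beyond the scatter above compound 1. Among the measured compounds shown here, the one step between compounds that differ in a single place, a number 2.6 percentage points higher from compound 2 to compound 3 (within the scatter), concerns a halogen on an aromatic carbon and says nothing about the chain bound to the core nitrogen.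

Compound 4 `CCCCn1c(CN2CCN(C(=O)C3CC3)CC2)nc2ccccc21` differs from compound 1 only in propyl in place of isopropyl on a saturated chain carbon bound to an aromatic nitrogen, the same atoms joined differently. For the measured compounds named here, no measured pair carries this change, or any change on the saturated chain carbon bound to the aromatic nitrogen, so no step size can be read from the data; the only known step, between compound 2 and compound 3, is of another kind and lies within the scatter. The step from compound 1 to compound 4 in this assay is therefore expected to be a number 0.1 percentage points lower from compound 1 to compound 4 (within the scatter), nothing beyond the scatter. Compound 4 is expected to give 13% in this assay, with a range from 4% to 24%.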

Compound 4, a percentage reported as inhibition, at one concentration (the size of the read-out at that concentration, not a potency): 18.2%
The estimate for compound 4 lay 5.2 percentage points below the measured number; low and high end bracket the measured number.
By their numbers in this assay, from the lowest: compounds 1, 4, 2 and 3 (each within the scatter of the next, the first and the last beyond it).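

Propyl in place of isopropyl on a saturated chain carbon bound to an aromatic nitrogen now has a size in this assay, the first at this position: a number 5.1 percentage points higher from compound 1 to compound 4 (within the scatter). With the rest of compound 1 unchanged, this read-out does not tell these two arrangements of the same atoms apart, so the shape of this chain, across this one pair, has not been shown to matter. Nothing available bears on the reason for this step.

Compound 2 and compound 3 differ from compound 1 and compound 4 in more than one place, so steps to them cannot be read, and the effect of their group at this position stays unresolved. As far as these compounds go, whether a longer chain such as octyl, or a chain ending in an amine or a carboxylic acid, would move the number beyond the scatter also remains open.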